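Swapping a six-membered ring for a five-membered one

A few compounds are considered here, and "the series" means these few. Any claim that something is new, unique, unknown or untested is made for them only; others in the source may bear on it.

Measured in a physicochemical assay for solubility, read by spectrophotometry, measured as kinetic solubility, at pH 8, tested at 500 uM; a higher number here means a more soluble compound, a lower number a less soluble compound:
compound 1 `Cn1ccc2ccc(-c3cc(Nc4ccccc4S(N)(=O)=O)cc4nccnc34)cc21`: 6 ug/mL
compound 2 `CN1CCCC(NS(=O)(=O)c2ccccc2Nc2cc(-c3ccc4ccn(C)c4c3)c3nccnc3c2)C1`: 9 ug/mL

Among the measured compounds shown here, compound 2 cannot be told apart from compound 1 on these numbers, since the only measured step is a 1.5-fold higher number from compound 1 to compound 2 (0.18 log units; within the scatter). That step put 1-methylpiperidin-3-yl in place of hydrogen on a sulfonamide nitrogen.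

Compound 3 `CN1CCC(NS(=O)(=O)c2ccccc2Nc2cc(-c3ccc4ccn(C)c4c3)c3nccnc3c2)C1` changes that same group: 1-methylpyrrolidin-3-yl takes the place of 1-methylpiperidin-3-yl on a sulfonamide nitrogen, and the count of the swap reads (1-methylpyrrolidin-3-yl in place of 1-methylpiperidin-3-yl on a sulfonamide nitrogen). For the measured compounds named here, no measured pair shows this ring swap directly, so the one measured step at this nitrogen is the only guide. Adding the whole group gave a 1.5-fold higher number from compound 1 to compound 2 (0.18 log units; within the scatter), so no step beyond the scatter is expected in this assay here. The expected step is a 1.1-fold higher number from compound 2 to compound 3 (0.05 log units; within the scatter). For compound 3 the estimated value is 10 ug/mL, with an expected range of 5 ug/mL to 21 ug/mL.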

Compound 3, solubility: 26 ug/mL
For compound 3 the middle estimate is 2.6-fold (0.41 log units) below the measured one; measured number above the stated range.
By their numbers in this assay, from the lowest: compounds 1 and 2 (each within the scatter of the next); then compound 3.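

In this assay the ring swap on the sulfonamide nitrogen gives a 2.9-fold higher number from compound 2 to compound 3 (0.46 log units; beyond the scatter) and so moves the number beyond the scatter, which putting 1-methylpiperidin-3-yl on this nitrogen did not do. Set against the hydrogen on that nitrogen, 1-methylpyrrolidin-3-yl gives a 4.3-fold higher number from compound 1 to compound 3 (0.64 log units; beyond the scatter) and so stands clear of it where 1-methylpiperidin-3-yl did not. At this position, then, the number depends on which ring is attached and not only on whether a ring is there, though nothing at hand says why the five-membered ring gives the higher number.

As far as these compounds go, what remains open is how far this goes with other groups on the same nitrogen, such as 1-methylazetidin-3-yl or an open-chain amine. The compounds shown also do not say whether the methyl on the ring nitrogen plays any part in this step.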